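The compounds below may be only part of what the source reports. "The series", "measured", "known", "first", "only" and "open" are said of these compounds alone.

Measured compounds:
- compound 1, `CCCCCCCCN(CCCCCCCC)CCCOc1ccc(S(=O)(=O)c2c(C(C)C)cn3ccccc23)cc1`: 30100 nM
- compound 2, `CCCCCN(CCCCC)CCCOc1ccc(S(=O)(=O)c2c(C(C)C)cn3ccccc23)cc1`: 89.6 nM
- compound 3, `CCCCCN(CCCCC)CCCOc1ccc(S(=O)(=O)c2c(CC)cn3ccccc23)cc1`: 62.4 nM

In a functional assay (aorta) with Rattus norvegicus as the target (on this read-out higher numbers stand for weaker inhibition and lower numbers for stronger inhibition), compound 2 gives 89.6 nM, the second highest of the three numbers. Its nearest neighbour is compound 3, reached by a 1.4-fold lower number from compound 2 to compound 3 (0.16 log units; within the scatter); its furthest is compound 1, whose value in this assay is 30100 nM, far beyond the scatter.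

Compound 4, `CC(C)c1cn2ccccc2c1S(=O)(=O)c1ccc(OCCCNC(C)(C)C)cc1`, carries (tert-butyl)amino in place of dipentylamino on a saturated chain carbon, three bonds along the chain from an oxygen on an aromatic ring. Among the measured compounds shown here, the one measured step, from compound 2 to compound 3, changes the chain on the shared core, not the amine, so it does not bear directly on this change. What compound 1 and compound 2 show together is that the amine substituents can move the number a long way. The smaller, donor-bearing amine in compound 4 is without precedent here, so the direction is uncertain; a modest move, if any, is expected. Compound 4 is therefore estimated at 150 nM, between 30 nM and 800 nM, meaning an expected step of a 1.7-fold higher number from compound 2 to compound 4 (0.22 log units; within the scatter).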

Compound 4, half-maximal inhibitory concentration: 41.8 nM
Beside the measured number, compound 4's estimate is 3.6-fold (0.55 log units) above it; the range from low to high includes it.
By their numbers in this assay, from the lowest: compounds 4, 3 and 2 (each within the scatter of the next, the first and the last beyond it); then compound 1.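

In this assay, (tert-butyl)amino in place of dipentylamino on this saturated chain carbon gives a 2.1-fold lower number from compound 2 to compound 4 (0.33 log units; beyond the scatter) and so a modest gain in inhibition. The earlier compounds shown here showed only that lengthening the amine chains could cost a great deal, with compound 1 at 30100 nM; this step shows that the position also accepts a much smaller amine, and one bearing a hydrogen-bond donor, without any loss. Nothing shown accounts for the gain.

The compounds shown leave open whether the gain belongs to the smaller size of the amine or to its remaining nitrogen hydrogen, which a straight-chain butylamino or a piperidine ring could help to separate. They also leave open whether (tert-butyl)amino would behave the same way alongside the ethyl group of compound 3.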